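Chloro to methyl on the anilide ring: an expected step

A few compounds are considered here, and "the series" means these few. Any claim that something is new, unique, unknown or untested is made for them only; others in the source may bear on it.

Compound 1 `Cc1ccc(N2C(=O)CSC2c2sc(Cc3ccc(Cl)cc3)nc2C)cc1` gives 81.3% in a functional assay on the whole organism (strain Wistar albino) for inhibition, with Rattus norvegicus as the target, read by paw edema, with stated times of 1 h and 4 h, at a dose of 40 mg/kg by the oral route; a lower number here means less inhibition, a higher number more inhibition at the dose given (going by the name of the read-out).
Compound 3 `Cc1nc(Cc2ccc(Cl)cc2)sc1C1SCC(=O)N1c1ccc(Cl)cc1` gives 53.9% in this assay.
Compound 2 `Cc1nc(-c2ccc(Cl)cc2)sc1C1SCC(=O)N1c1ccc(Cl)cc1` gives 43.2% in this assay.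

Compound 3 and compound 1 share one core and differ in a single place: methyl in place of chloro on an aromatic carbon. That change produced a number 27.4 percentage points higher from compound 3 to compound 1 (beyond the scatter). Compound 2 has a different core; the difference between the two cores is 4-chlorophenyl in place of 4-chlorobenzyl on an aromatic carbon, and read the other way, in this assay, it gave a number 10.7 percentage points higher from compound 2 to compound 3 (beyond the scatter). Compound 2 thus has the lowest of the three numbers, and its gaps to compound 3 and compound 1 are both beyond the scatter.

Compound 4 `Cc1ccc(N2C(=O)CSC2c2sc(-c3ccc(Cl)cc3)nc2C)cc1` is still unmeasured. It differs from compound 2 by methyl in place of chloro on an aromatic carbon, the same change as from compound 3 to compound 1, the place being described in the same words for both pairs. Compound 4 is therefore expected to give about 66% in this assay, within an expected range of 52% to 80%. The expected step of a number 22.8 percentage points higher from compound 2 to compound 4 (beyond the scatter) is set a little smaller than the earlier one, because a number 27.4 percentage points higher from compound 3 to compound 1 (beyond the scatter) rests on one pair only, on the other core, and the same change may not carry over in full.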

Compound 4, a percentage reported as inhibition, in the whole organism at one dose (the size of the read-out at that dose, not a potency): 63.9%
For compound 4 the middle estimate is 2.1 percentage points above the measured one; measured number inside the range.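

In this assay, methyl in place of chloro on an aromatic carbon again raised the number, giving a number 20.7 percentage points higher from compound 2 to compound 4 (beyond the scatter), so this change carried over to the second core at a similar size: the same change on two cores in this assay, a number 27.4 percentage points higher (beyond the scatter) from compound 3 to compound 1 and a number 20.7 percentage points higher (beyond the scatter) from compound 2 to compound 4, 6.7 percentage points apart, within the scatter of two such steps
The other change, 4-chlorophenyl in place of 4-chlorobenzyl, gave a number 17.4 percentage points lower from compound 1 to compound 4 (beyond the scatter), and it too behaved alike on both sides of the set: the same change on two cores in this assay, a number 10.7 percentage points higher (beyond the scatter) from compound 2 to compound 3 and a number 17.4 percentage points higher (beyond the scatter) from compound 4 to compound 1, 6.7 percentage points apart, within the scatter of two such steps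
Going by these compounds alone, this shows that, within these four compounds, each change had much the same effect whichever form the other place took, but it rests on only two pairs per change, read at one dose, and it neither shows that the step would hold on any other core nor explains why it occurs.

The compounds shown leave open whether a methoxy group, an amine or a carboxylic acid at the same place on the ring would continue the rise seen with methyl. They also leave open what a longer chain in place of the 4-chlorobenzyl group would do.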